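Aminothiazole acylguanidines: benzyl to hexyl on two cores

A few compounds are considered here, and "the series" means these few. Any claim that something is new, unique, unknown or untested is made for them only; others in the source may bear on it.

Three compounds have numbers in an assay on membranes from Sf9 cells for displacement of a labelled ligand from histamine H2 receptor (Homo sapiens), read by scintillation counting, with a stated time of 60 min; on this read-out lower numbers stand for stronger inhibition and higher numbers for weaker inhibition. Compound 1 `N/C(=N\C(=O)NCc1ccccc1)NC1CCc2nc(N)sc2C1` gives 513 nM in this assay, the highest of the three. Compound 3 `Cc1nc(N)sc1CCCN/C(N)=N/C(=O)NCc1ccccc1` gives 69.2 nM, and compound 2 `CCCCCCNC(=O)/N=C(\N)NCCCc1sc(N)nc1C` gives 28.8 nM. Compound 3 and compound 2 differ in one place, pentyl in place of phenyl on a saturated chain carbon bound to an amide-type nitrogen and that change gave a 2.4-fold lower number from compound 3 to compound 2 (0.38 log units; beyond the scatter). The difference between the core of compound 1 and the core of compound 3 is not broken down here.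

Compound 4 `CCCCCCNC(=O)/N=C(\N)NC1CCc2nc(N)sc2C1` has not yet been measured. It stands to compound 1 as compound 2 stands to compound 3: pentyl in place of phenyl on a saturated chain carbon bound to an amide-type nitrogen The place is described in the same words for both pairs, so this is the same change made on another core. The change has been measured once, on one pair only, and with two cores no pattern can be claimed. Compound 4 is expected to give 215 nM in this assay. The expected step is a 2.4-fold lower number from compound 1 to compound 4 (0.38 log units; beyond the scatter). This rests on carrying the measured 2.4-fold lower number from compound 3 to compound 2 (0.38 log units; beyond the scatter) over onto compound 1 at 513 nM. For compound 4 the expected range runs from 90 nM to 500 nM.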

Compound 4, inhibition constant: 1120 nM
Compound 4: middle estimate off by 5.2-fold (0.72 log units), on the low side; measured number above the stated range.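

In this assay the change from benzyl to hexyl does not carry from one core to the other, and the two steps run in opposite directions: the same change on two cores in this assay, a 2.4-fold lower number (0.38 log units; beyond the scatter) from compound 3 to compound 2 and a 2.2-fold higher number (0.34 log units; beyond the scatter) from compound 1 to compound 4, 5.2-fold (0.72 log units) apart, beyond the scatter of two such steps

The new step, a 2.2-fold higher number from compound 1 to compound 4 (0.34 log units; beyond the scatter), means that a step measured on one core is no guide here to either its direction or its size on the other core. The two pairs do not show why the cores part ways, and they say nothing about how the same change would behave on a third core.

Still open, from the compounds shown here alone, is whether the reversal belongs to benzyl and hexyl alone or extends to other groups at this place on the two cores. Matched pairs carrying an octyl chain or a phenethyl group on both cores would test this, and would show whether the order of the two cores holds beyond these compounds.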